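Ethynyl to iodo exchange on two related cores

The source may report more compounds than this note shows. Statements on the series, on what has been measured and on what is new or still open speak of the compounds shown alone.

Measured in a functional assay on K562 cells (Homo sapiens), read by MTT assay, with a stated time of 72 h; a higher number here means a weaker inhibitor, a lower number a stronger inhibitor:
compound 1 `Cc1ncnc2c1c(I)cn2[C@@H]1O[C@H](CO)[C@@H](O)[C@H]1O`: > 20000 nM, a limit of the assay
compound 2 `C#Cc1cn([C@@H]2O[C@H](CO)[C@@H](O)[C@H]2O)c2ncnc(C)c12`: 110 nM
compound 3 `C#Cc1cn([C@@H]2O[C@H](CO)[C@@H](O)[C@H]2O)c2nc(C)nc(N)c12`: 3290 nM

Compound 2 and compound 1 differ by iodo in place of ethynyl on an aromatic carbon, giving the step of an at least 180-fold higher number from compound 2 to compound 1 (2.25 log units; beyond the scatter). The number for compound 1 is a limit of the assay, (the limit of > 20000 nM in this assay, at which 1 of the 3 values shown sits). Compound 3 holds the highest of the two plain numbers against compound 2; the difference between the two cores is not broken down here. Compound 4 `Cc1nc(N)c2c(I)cn([C@@H]3O[C@H](CO)[C@@H](O)[C@H]3O)c2n1` is not yet measured and differs from compound 3 by iodo in place of ethynyl on an aromatic carbon, the same change as between compound 2 and compound 1. For compound 4 a step of a 30-fold higher number from compound 3 to compound 4 (1.48 log units; beyond the scatter) is expected in this assay, resting on the step of an at least 180-fold higher number from compound 2 to compound 1 (2.25 log units; beyond the scatter) and on compound 3 starting from 3290 nM. Compound 4 is therefore estimated at 100000 nM, most likely reported only as a limit.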

Compound 4, half-maximal inhibitory concentration: 1110 nM
Compound 4: the middle estimate sits 90-fold (1.95 log units) above what was measured; measured number outside the range, below it.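

In this assay, iodo in place of ethynyl on an aromatic carbon gives a 3.0-fold lower number from compound 3 to compound 4 (0.47 log units; beyond the scatter), so on this core the exchange does not cost activity as it did on the core of compound 2. From the compounds shown here alone, the outcome of this change therefore does not carry from one core to the other in these two pairs: the same change on two cores in this assay, an at least 180-fold higher number (2.25 log units; beyond the scatter) from compound 2 to compound 1 and a 3.0-fold lower number (0.47 log units; beyond the scatter) from compound 3 to compound 4, at least 530-fold (2.73 log units) apart, beyond the scatter of two such steps These two pairs do not show which difference between the cores sets the outcome, and compound 1 is recorded only as a limit, so the full size of the earlier step is unknown. Open remains whether a nitrile or a bromo on the same aromatic carbon would follow compound 1 or compound 4 on each core.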